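Moving the Fluorine on the Benzylidene Ring

A few compounds are considered here, and "the series" means these few. Any claim that something is new, unique, unknown or untested is made for them only; others in the source may bear on it.

Two compounds have been measured in a functional assay on HepG2 cells (Homo sapiens) for inhibition, read by MTT assay, with a stated time of 48 h; on this read-out lower numbers stand for stronger inhibition and higher numbers for weaker inhibition:
Compound 1, `COc1ccc(/C=N/NC(=O)CSc2nnc(-c3ccncc3)n2-c2ccccc2)cc1`, gives 27100 nM.
Compound 2, `O=C(CSc1nnc(-c2ccncc2)n1-c1ccccc1)N/N=C/c1ccc(F)cc1`, gives 9330 nM.

Among the compounds with values here, compound 2 holds the lowest of the two numbers in this assay, and the only measured step, a 2.9-fold lower number from compound 1 to compound 2 (0.46 log units; beyond the scatter), is what separates it from compound 1. That step swaps one group for another of a different kind; it says nothing about what happens when the same group is kept but moved to another carbon of the ring.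

Compound 3, `O=C(CSc1nnc(-c2ccncc2)n1-c1ccccc1)N/N=C/c1ccccc1F`, is exactly that kind of change: 2-fluorophenyl in place of 4-fluorophenyl on a carbon with a double bond to nitrogen. Within the data shown here, both partners have the same atoms, only joined differently, so no measured step bears on it. With nothing to lean on beyond the shared core and the unchanged fluorine, the expectation is a step from compound 2 to compound 3 that stays within the usual scatter, a 1.0-fold higher number from compound 2 to compound 3 (0.01 log units; within the scatter), in either direction. Compound 3 is therefore estimated at 9500 nM in this assay, with a range from 3500 nM to 28000 nM.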

Compound 3, half-maximal inhibitory concentration: 15200 nM
Compound 3: middle estimate off by 1.6-fold (0.20 log units), on the low side; low and high end bracket the measured number.
By their numbers in this assay, from the lowest: compounds 2, 3 and 1 (each within the scatter of the next, the first and the last beyond it).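

In this assay the move of the fluorine gives a 1.6-fold higher number from compound 2 to compound 3 (0.21 log units; within the scatter) and so stays inside the normal noise of the measurement: on this core, 2-fluorophenyl and 4-fluorophenyl on a carbon with a double bond to nitrogen cannot be told apart by these numbers. The second new step, a 1.8-fold lower number from compound 1 to compound 3 (0.25 log units; within the scatter) on the same read-out, is also within the scatter, so compound 3 cannot be separated from compound 1 either, even though a 2.9-fold lower number from compound 1 to compound 2 (0.46 log units; beyond the scatter) puts the two earlier compounds beyond the scatter of each other; compound 3 therefore sits in the gap between them and does not sharpen the difference they showed. Nothing measured here offers an explanation for any of these numbers.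

Going by these compounds, whether the methoxy group would behave as the fluorine did when moved around the ring remains open, and so does whether a chlorine, an amine or a carboxylic acid on this ring would shift the number by more than the scatter. The compounds shown also leave open what a change anywhere else on the shared core would do, since all three differ only on this one ring.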